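Swapping Fluoro for Cyano on a Benzyl Arm

The source may report more compounds than this note shows. Statements on the series, on what has been measured and on what is new or still open speak of the compounds shown alone.

Compound 3 `COc1ccc(F)cc1CNCCCNc1ccnc2cc(Cc3ccc(F)cc3)ccc12` is one of three compounds with a shared core that have been tested in an ADME assay for permeability, using PAMPA, with a stated time of 30 min, at pH 7.4; a lower number here means that the compound crosses the layer more slowly, a higher number that the compound crosses the layer faster. In this assay compound 3 gives 23 10^-6 cm/s. Compound 1 `COc1ccc(F)cc1CNCCCNc1ccnc2cc(CCC(C)C)ccc12` gives 23 10^-6 cm/s, so the two stand level and are together the lowest of the three numbers; the step is no change at the digits printed from compound 1 to compound 3 (within the scatter). Compound 2 `COc1cccc(Oc2ccc3c(NCCCNCc4cc(F)ccc4OC)ccnc3c2)c1` gives 317 10^-6 cm/s, and the step of a 14-fold lower number from compound 2 to compound 3 (1.14 log units; beyond the scatter) is the only large movement among the three.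

Compound 4 `COc1ccc(F)cc1CNCCCNc1ccnc2cc(Cc3ccc(C#N)cc3)ccc12` has not yet been measured. It differs from compound 3 in one place: cyano in place of fluoro on an aromatic carbon.

For the measured compounds named here, none of the measured steps swaps one small group for another in this way. The step of no change at the digits printed from compound 1 to compound 3 (within the scatter) replaced isobutyl with 4-fluorophenyl and left the number where it was, while a 14-fold higher number from compound 1 to compound 2 (1.14 log units; beyond the scatter) came from a quite different change, 3-methoxyphenoxy in place of isopentyl. Going by the values given here, the data hold no step from fluoro to cyano, so the expected step of a 1.3-fold lower number from compound 3 to compound 4 (0.11 log units; within the scatter) is one that stays within the usual scatter. The estimate for compound 4 is therefore 18 10^-6 cm/s, with a range from 8 10^-6 cm/s to 40 10^-6 cm/s.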

Compound 4, apparent permeability: 23 10^-6 cm/s
The estimate for compound 4 lay 1.3-fold (0.11 log units) below the measured number; the range from low to high includes it.
By their numbers in this assay, from the lowest: compounds 1, 3 and 4 (each within the scatter of the next); then compound 2.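

In this assay, putting cyano in place of fluoro, on an aromatic carbon para to a large group, gives no change at the digits printed from compound 3 to compound 4 (within the scatter), the first direct view of a swap of one small group for another at this place. Cyano brings one more heavy atom and one hydrogen-bond acceptor than fluoro, yet the read-out stays level, and the comparison with the isobutyl side of the series, no change at the digits printed from compound 1 to compound 4 (within the scatter), tells the same story, while a 14-fold lower number from compound 2 to compound 4 (1.14 log units; beyond the scatter) shows that the 4-cyanobenzyl compound sits as far from the 3-methoxyphenoxy compound as the 4-fluorobenzyl compound does. No measurement shown here bears on what lies behind this flat result.

As far as these compounds go, only fluoro and cyano have been compared at this place on the ring, so it remains open whether the number would also hold with an amine or a carboxylic acid there. From the compounds shown here alone, it also remains open which part of the 3-methoxyphenoxy group goes with the high value of compound 2, 317 10^-6 cm/s, and whether a plain phenoxy group or a longer chain carrying an ether oxygen would sit near that value or near the others.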